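Trifluoromethyl in place of bromo on the shared core

The compounds below may be only part of what the source reports. "The series", "measured", "known", "first", "only" and "open" are said of these compounds alone.

Measured compounds:
Compound 1, `O=C(O)c1ccn(Cc2cc(Br)ccc2OCc2ccccc2)n1`: in a functional assay on CHO-K1 cells for antagonist activity at prostaglandin E2 receptor EP1 subtype (Homo sapiens), read by FLIPR (a higher number here means a weaker inhibitor, a lower number a stronger inhibitor), compound 1 gives 55 nM.
Compound 2, `O=C(O)c1nn(Cc2cc(Br)ccc2OCc2ccccc2)cc1Br`: for compound 2 this assay reports only a limit, < 2000 nM.

Compound 2 therefore stands on a limit and not on a number, so its exact position against compound 1 cannot be read. Among the measured compounds shown here, the single measured step, from compound 1 to compound 2, is a step that the limit leaves unreadable from compound 1 to compound 2; its size stays hidden because of the limit of < 2000 nM in this assay, at which 1 of the 2 values shown sits. Compound 3, `O=C(O)c1nn(Cc2cc(Br)ccc2OCc2ccccc2)cc1C(F)(F)F`, differs from compound 2 by trifluoromethyl in place of bromo on an aromatic carbon. For the measured compounds named here, no measured step involves a trifluoromethyl, and the one step that touches this same ring carbon cannot be sized, so there is no ground for expecting a shift beyond the scatter in either direction in this assay. Compound 3 is expected to land near where compound 2 sits, with a wide range. The step from compound 2 to compound 3 is estimated as a step that the limit leaves unreadable from compound 2 to compound 3. Compound 3 is estimated at 400 nM, between 60 nM and 2500 nM.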

Compound 3, inhibition constant: < 2000 nM
Compound 3: only a limit was reported; the forecaster's own chance of this, stated with the estimate: 30%; the middle value is on the limit's open side.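

In this assay, among the compounds shown here, compound 3 gives < 2000 nM which is a limit and not a number, as with compound 2, so no step among compound 1, compound 2 and compound 3 can be read: the limit of < 2000 nM in this assay, at which 2 of the 3 values shown sit. Still open, going by these compounds, is how far bromo or trifluoromethyl on the shared core moves the inhibition constant from that of compound 1, and whether these two groups differ.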